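Swapping a benzoyl for a 2-chlorophenyl on the sulfonamide

The compounds below may be only part of what the source reports. "The series", "measured", "known", "first", "only" and "open" are said of these compounds alone.

Compound 2 `O=C(NS(=O)(=O)c1ccc(NC(=O)c2ccc(Cl)cc2Cl)cc1)c1ccccc1` has no number in a functional assay on HEK293 cells for agonist activity at probable G-protein coupled receptor 27 (Homo sapiens), read by a luciferase reporter and beta-arrestin recruitment, with a stated time of 10 min; on this read-out lower numbers stand for smaller maximal responses and higher numbers for larger maximal responses: its result there reads "not determined" (no result reported). The same holds for compound 3 `O=S(=O)(Nc1ccccc1)c1ccc(NS(=O)(=O)c2ccc(Cl)cc2Cl)cc1`, which reads "not determined" (no result reported). Among the compounds with values here, the only measured neighbour is compound 1 `O=C(Nc1ccc(S(=O)(=O)Nc2ccccc2)cc1)c1ccc(Cl)cc1F`, which reaches 57%. Compound 4 `O=C(Nc1ccc(S(=O)(=O)Nc2ccccc2Cl)cc1)c1ccc(Cl)cc1Cl` differs from compound 2 by 2-chlorophenyl in place of benzoyl on a sulfonamide nitrogen. With no number for compound 2 in this assay, no direction or size for the move from compound 2 to compound 4 can be given; it stays an open expectation. Compound 4 shares its overall layout with compound 1, so its maximal response is estimated near 55%, with a likely range from 25% to 85%.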

Compound 4, largest response reached (Emax), in percent of the reference or control that the assay uses: 53%
The estimate for compound 4 lay 2 percentage points above the measured number, and the stated range covers the measured number.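

In this assay no new step can be read between compound 4 and compound 2 or compound 1. What swapping benzoyl for 2-chlorophenyl does to the maximal response stays open, and nothing shown here offers an explanation for the result of compound 4.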